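A few compounds are considered here, and "the series" means these few. Any claim that something is new, unique, unknown or untested is made for them only; others in the source may bear on it.

The series shares a core in which a seven-membered sulfur-containing ring is fused to a benzene ring that carries a variable substituent. Compound 1 `CC1(C)CS(=O)(=O)c2ccc(N)cc2[C@@H](c2ccccc2)[C@H]1O` has two methyl groups on the sulfur-containing ring and a plain amino group on the aromatic ring. In an assay on cells for inhibition of ileal sodium/bile acid cotransporter (Homo sapiens) (a higher number here means a weaker inhibitor, a lower number a stronger inhibitor), compound 1 returns only a limit, > 50000 nM, so no number is available for it; this is the situation described by the limit of > 50000 nM in this assay, at which 1 of the 2 values shown sits. For the measured compounds named here, compound 2 `CCCCC1(CCCC)CS(=O)(=O)c2ccc([N+](C)(C)C)cc2[C@@H](c2ccccc2)[C@H]1O` carries two butyl chains and a trimethylammonium group, and in this assay compound 2 gives 210 nM, the only real number so far. Compound 3 `CCCCC1(CCCC)CS(=O)(=O)c2ccc(NC(=O)OCc3ccccc3)cc2[C@@H](c2ccccc2)[C@H]1O` keeps the two butyl chains but changes the aromatic substituent: a group of 11 heavy atoms (8 carbon, 1 nitrogen, 2 oxygen; one six-membered aromatic ring of carbon only) in place of a group of 4 heavy atoms (3 carbon, 1 nitrogen; no ring), on an aromatic carbon. Going by the values given here, no step between two measured compounds is available to guide this change, so only a rough expectation is possible. Compound 3 is expected to give 150 nM, within a range of 30 nM to 1000 nM, which means an estimated step of a 1.4-fold lower number from compound 2 to compound 3 (0.15 log units; within the scatter) that is not expected to exceed the scatter by much in either direction.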

Compound 3, half-maximal inhibitory concentration: 600 nM
Compound 3: the middle estimate sits 4.0-fold (0.60 log units) below what was measured, and the stated range covers the measured number.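

Holding the two butyl chains fixed gives the first change at a single place in this series: in this assay, the (benzyloxycarbonyl)amino group in place of the trimethylammonium group gives a 2.9-fold higher number from compound 2 to compound 3 (0.46 log units; beyond the scatter). Compound 3 still returns a real number, 600 nM, so on this core a net positive charge on this aromatic carbon is not required for a measurable value, and a much larger group that carries its own aromatic ring is compatible with one. For the compounds shown here, nothing measured so far explains the size or direction of this step.

Going by these compounds, the charge, the size and the hydrogen-bond donor all change together in this one step, so their separate contributions remain open. A dimethylamino group or a carboxylic acid at this position, with the two butyl chains kept, would help to pull them apart.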